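This account rests on a few compounds, and the source may have more. Where it says the series, first, only, none or still open, it means among the compounds named here.

Measured so far:
compound 1 `CNC(=O)c1cc(C(=O)NC2CCC2)cn(Cc2cccc(NC)c2)c1=O`, 3.6
compound 2 `CNC(=O)c1cc(C(=O)NCCC2CCOCC2)cn(Cc2ccccc2)c1=O`, 3.6

Within the data shown here, in a physicochemical assay for lipophilicity, at pH 7.4 (a higher number here means a more lipophilic compound, a lower number a more polar compound), compound 1 gives 3.6 and compound 2 gives 3.6; compound 1 stands level with compound 2, within the scatter, and no step between these two is counted. Compound 3 `CNC(=O)c1cc(C(=O)NC2CCC2)cn(Cc2cccnc2)c1=O` is not yet measured. It differs from compound 1 in one place: pyridin-3-yl in place of 3-(methylamino)phenyl on a saturated chain carbon bound to an aromatic nitrogen. Among the measured compounds shown here, no measured pair carries this change, so its size rests on expectation alone. The step of a number 1.20 log units lower from compound 1 to compound 3 (beyond the scatter) is expected to be a drop beyond the scatter. For compound 3 the expected value is 2.4, with a range from 1.8 to 3.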

Compound 3, distribution coefficient: 1.8
For compound 3 the middle estimate is 0.60 log units above the measured one; the range from low to high includes it.
By their numbers in this assay, from the lowest: compound 3; then compounds 1 and 2 (each within the scatter of the next).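

In this assay, among these compounds, pyridin-3-yl in place of 3-(methylamino)phenyl on a saturated chain carbon bound to an aromatic nitrogen gives a number 1.80 log units lower from compound 1 to compound 3 (beyond the scatter) and this is the first one-place step. It shows that the read-out responds strongly to this exchange at this position, which the earlier level pair could not show. The step is a single pair, so it sets no trend.

As far as these compounds go, how a pyridin-4-yl or a 3-aminophenyl would read at this position, with the rest of compound 1 unchanged, remains open. No measurement shown accounts for the size of this step.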